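Swapping 3,4-dimethoxyphenyl for 4-nitrophenyl on the shared core

This account rests on a few compounds, and the source may have more. Where it says the series, first, only, none or still open, it means among the compounds named here.

Within the data shown here, in a functional assay on MOLT-4 cells (Homo sapiens) for antiproliferative activity (on this read-out higher numbers stand for weaker inhibition and lower numbers for stronger inhibition), compound 2 (`COc1ccc(-c2cc(N)c(C(=O)c3cc(OC)c(OC)c(OC)c3)s2)cc1OC`) gives 20 nM, the lowest of two numbers so far, and compound 1 (`COc1cc(C(=O)c2sc(-c3ccc(Br)cc3)cc2N)cc(OC)c1OC`) gives 92 nM. Compound 3 (`COc1cc(C(=O)c2sc(-c3ccc([N+](=O)[O-])cc3)cc2N)cc(OC)c1OC`) differs from compound 2 at one place: 4-nitrophenyl in place of 3,4-dimethoxyphenyl on an aromatic carbon. Among the measured compounds shown here, one measured step bears on this place: a 4.6-fold lower number from compound 1 to compound 2 (0.66 log units; beyond the scatter), a modest change on going to 3,4-dimethoxyphenyl from 4-bromophenyl. Compound 3 also lacks 3,4-dimethoxyphenyl, so a reversal of similar size towards a higher number is expected in this assay. The expected step is a 4.5-fold higher number from compound 2 to compound 3 (0.65 log units; beyond the scatter). For compound 3 the estimated value is 90 nM, with an expected range of 25 nM to 320 nM.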

Compound 3, half-maximal inhibitory concentration: 110 nM
The estimate for compound 3 lay 1.2-fold (0.09 log units) below the measured number; low and high end bracket the measured number.
By their numbers in this assay, from the lowest: compound 2; then compounds 1 and 3 (each within the scatter of the next).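

In this assay, a second replacement of 3,4-dimethoxyphenyl at this place next to the ring sulfur also gives a higher number, here with 4-nitrophenyl (a 5.5-fold higher number from compound 2 to compound 3 (0.74 log units; beyond the scatter)). Nitro in place of bromo makes no difference beyond the scatter (a 1.2-fold higher number from compound 1 to compound 3 (0.08 log units; within the scatter)), so 4-bromophenyl and 4-nitrophenyl cannot be told apart on this read-out, while 3,4-dimethoxyphenyl stands apart from both. No measurement at hand explains this difference.
From the compounds shown here alone, whether a single methoxy, as in 4-methoxyphenyl, matches 3,4-dimethoxyphenyl remains open. So does the outcome with an amine or a carboxylic acid on this phenyl ring.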